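A few compounds are considered here, and "the series" means these few. Any claim that something is new, unique, unknown or untested is made for them only; others in the source may bear on it.

Measured compounds
compound 1 `COc1ccc2c(=O)c(/C=C/C(=O)Nc3cccc(Cl)c3)coc2c1`: 470 nM
compound 2 `COc1ccc2c(=O)c(/C=C/C(=O)Nc3ccc(Cl)cc3)coc2c1`: > 100000 nM (a limit of the measurement)
compound 3 `CCOc1ccc(NC(=O)/C=C/c2coc3cc(OC)ccc3c2=O)cc1`: > 100000 nM (a limit of the measurement)

In a functional assay on A549 cells (Homo sapiens) for inhibition, read by MTT assay, with a stated time of 48 h (a lower number here means a stronger inhibitor, a higher number a weaker inhibitor), compound 3 gives only > 100000 nM, a boundary of the measurement rather than a number. Compound 2 likewise rests at a limit, (the limit of > 100000 nM in this assay, at which 2 of the 3 values shown sit). Compound 4 `COc1ccc(NC(=O)/C=C/c2coc3cc(OC)ccc3c2=O)cc1` differs from compound 3 by hydrogen in place of methyl on a saturated chain carbon bound to an oxygen on an aromatic ring. For the measured compounds named here, no measured step touches this change directly. The steps of an at least 210-fold higher number from compound 1 to compound 2 (2.32 log units; beyond the scatter) and an at least 210-fold higher number from compound 1 to compound 3 (2.32 log units; beyond the scatter) place both 4-substituted anilides at the limit, while a step that the two limits leave unreadable from compound 2 to compound 3. With compound 3 already at a limit, the expected step is a number no higher from compound 3 to compound 4 (the limit leaves the size open), and compound 4 is most likely again reported only as a limit. Compound 4 is estimated at 100000 nM, with a range from 20000 nM to 300000 nM.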

Compound 4, half-maximal inhibitory concentration: 23000 nM
Compound 4: the middle estimate sits 4.3-fold (0.64 log units) above what was measured; the range from low to high includes it.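

Ethoxy to methoxy in this assay gives an at least 4.3-fold lower number from compound 3 to compound 4 (0.63 log units; beyond the scatter), so a 4-substituted anilide can leave the limit, and one carbon on this chain is enough to show it. Methoxy in place of chloro gives an at least 4.3-fold lower number from compound 2 to compound 4 (0.63 log units; beyond the scatter), so the substituent itself counts, not only where it sits on the phenyl. The 3-chlorophenyl anilide still reads far better, with a 49-fold higher number from compound 1 to compound 4 (1.69 log units; beyond the scatter). The compounds shown leave open how a hydroxy group or an amine in place of the methoxy would read, and whether 3-methoxyphenyl would come close to compound 1.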